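Urea replacement at the amide carbonyl in the sulfonamide series

A few compounds are considered here, and "the series" means these few. Any claim that something is new, unique, unknown or untested is made for them only; others in the source may bear on it.

Measured so far:
compound 1 `COC(=O)c1ccc(C(=O)Nc2cccc3c2N(S(=O)(=O)c2ccc(OC)cc2)CC3)cc1`: 312 nM
compound 2 `COc1ccc(S(=O)(=O)N2CCc3cccc(NC(=O)c4ccco4)c32)cc1`: 10.7 nM

In a functional assay on MKN-45 cells (Homo sapiens) for cytotoxicity (a lower number here means a stronger inhibitor, a higher number a weaker inhibitor), compound 1 gives 312 nM, the highest of the two numbers in hand; its nearest neighbour is compound 2, which in this assay gives 10.7 nM. Within the data shown here, the single step that joins them, a 29-fold lower number from compound 1 to compound 2 (1.46 log units; beyond the scatter), is the only measured change on this carbonyl carbon, and it is large.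

Compound 3 `COc1ccc(S(=O)(=O)N2CCc3cccc(NC(=O)N(C)c4ccccc4)c32)cc1` is not yet measured. Relative to compound 1 the change is methyl(phenyl)amino in place of 4-(methoxycarbonyl)phenyl on a carbonyl carbon. The measured step from compound 1 to compound 2 bears on it only loosely: it shows that the 4-(methoxycarbonyl)phenyl group on this carbonyl carbon is not required for a low number in this assay and that its removal can give a large drop, but the entering group there, furan-2-yl, is not the entering group here. Among the measured compounds shown here, no measured pair shows methyl(phenyl)amino on the carbonyl carbon. A step in the same direction as compound 1 to compound 2, but of smaller size and with wide uncertainty, is therefore expected for compound 3 in this assay: a 2.6-fold lower number from compound 1 to compound 3 (0.41 log units; beyond the scatter). The expected value for compound 3 is 120 nM, within 25 nM to 600 nM.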

Compound 3, half-maximal inhibitory concentration: > 10000 nM
Compound 3 ended at the assay's limit; the forecaster's own chance of this, stated with the estimate: 5%; at least 83-fold (1.92 log units) between middle value and limit.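

In this assay compound 3 stands at a limit of the assay and not at a number: the limit of > 10000 nM in this assay, at which 1 of the 3 values shown sits. Both steps onto methyl(phenyl)amino run upward, an at least 32-fold higher number from compound 1 to compound 3 (1.50 log units; beyond the scatter) and an at least 930-fold higher number from compound 2 to compound 3 (2.97 log units; beyond the scatter), so this carbonyl carbon does not accept every replacement for 4-(methoxycarbonyl)phenyl. The earlier pair showed only that losing 4-(methoxycarbonyl)phenyl can lower the number; compound 3 shows that the same loss can also raise it, so the entering group matters, and keeping a six-membered aromatic ring of carbon only on this side is not enough for a low number.

The three compounds do not separate the parts of methyl(phenyl)amino, leaving open whether the high reading follows the nitrogen on the carbonyl carbon, its methyl or its phenyl. Phenylamino, which lacks the methyl, and dimethylamino, which lacks the phenyl, on the same carbonyl carbon of the shared core would divide these readings, and a result near that of compound 2 for either would place the loss in the missing part's counterpart.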